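Replacing the Benzyl Ring of Compound 1: What to Expect

The source may hold more compounds than are shown below. What is called first, only, known or untested is meant among the compounds shown, and "the series" means these compounds.

Measured in a functional assay on A2780 cells (Homo sapiens) for inhibition, read by MTT assay, with a stated time of 72 h; on this read-out lower numbers stand for stronger inhibition of growth and higher numbers for weaker inhibition of growth:
- compound 1 `CC(C)(C)c1ccc(CNCCCNS(=O)(=O)c2cc(C(F)(F)F)cc(C(F)(F)F)c2)cc1` gives 2900 nM
- compound 2 `O=S(=O)(NCCNCc1ccc(-c2ccccc2)cc1)c1cc(C(F)(F)F)cc(C(F)(F)F)c1` gives 2600 nM
- compound 3 `O=S(=O)(NCCCCNCc1ccc(Br)cc1)c1cc(C(F)(F)F)cc(C(F)(F)F)c1` gives 2100 nM

Compound 1 carries the highest of the three numbers in this assay, but the gaps to compound 2 and to compound 3 are both within the usual scatter of repeated measurements, so the three compounds cannot be told apart on this read-out. Among the measured compounds shown here, no step between two measured compounds differing in one place is available; the three differ from one another in more than one place at a time.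

Compound 4 `O=S(=O)(NCCCNCc1ccc(Cl)c(C(F)(F)F)c1)c1cc(C(F)(F)F)cc(C(F)(F)F)c1` is obtained from compound 1 by the change (4-chloro-3-(trifluoromethyl)phenyl in place of 4-(tert-butyl)phenyl on a saturated chain carbon bound to an amine nitrogen). Since the measured compounds already span several different aryl groups and chain lengths without any difference beyond the scatter, the change from compound 1 to compound 4 is expected to move the number little. The estimated step of a 1.2-fold lower number from compound 1 to compound 4 (0.06 log units; within the scatter) is expected to be none beyond the scatter. In this assay compound 4 is therefore expected to give about 2500 nM, within a range from 1000 nM to 6500 nM.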

Compound 4, concentration for 50% growth inhibition: 5900 nM
Beside the measured number, compound 4's estimate is 2.4-fold (0.37 log units) below it, within the range that was stated.
By their numbers in this assay, from the lowest: compounds 3, 2 and 1 (each within the scatter of the next); then compound 4.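

In this assay, placing 4-chloro-3-(trifluoromethyl)phenyl in place of 4-(tert-butyl)phenyl on a saturated chain carbon bound to an amine nitrogen gives a 2.0-fold higher number from compound 1 to compound 4 (0.31 log units; beyond the scatter), a modest step. Among the compounds shown here, this is the only comparison here between compounds that differ in one place, and it shows that a change of this group alone, with the rest of compound 1 kept, can move the number beyond the scatter, which the earlier compounds, differing in more than one place, could not show. Nothing measured here accounts for this step.

As far as these compounds go, whether an unsubstituted phenyl or a pyridine ring in this place would give a lower or a higher number remains open. So does whether the same exchange would have a similar effect on a shorter or a longer chain.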